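Compound 3: a bromophenyl group replaces the hydroxyphenyl

The source may report more compounds than this note shows. Statements on the series, on what has been measured and on what is new or still open speak of the compounds shown alone.

Measured in a functional assay on T47D cells (Homo sapiens) for inhibition, read by CCK-8 assay, with a stated time of 72 h, tested at 10 uM; a lower number here means less inhibition of growth, a higher number more inhibition of growth at the concentration tested:
- compound 1 `Cc1cccc(NC(=O)C2(C(=O)Nc3ccc(Nc4ncc5cc(C(=O)N(C)C)n(C6CCCC6)c5n4)cc3)CC2)c1`: 95.3%
- compound 2 `CN(C)C(=O)c1cc2cnc(Nc3ccc(NC(=O)C4(C(=O)Nc5cccc(O)c5)CC4)cc3)nc2n1C1CCCC1`: 83.7%

Of the two measured compounds, compound 2 stands lower, with 83.7%, and its gap to compound 1 lies beyond the scatter. The next compound, compound 3 `CN(C)C(=O)c1cc2cnc(Nc3ccc(NC(=O)C4(C(=O)Nc5ccc(Br)cc5)CC4)cc3)nc2n1C1CCCC1`, keeps the shared core and differs from compound 2 only on an amide-type nitrogen, where 4-bromophenyl stands in place of 3-hydroxyphenyl: 4-bromophenyl in place of 3-hydroxyphenyl on an amide-type nitrogen.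

For the measured compounds named here, one measured step bears on this change: a number 11.6 percentage points lower from compound 1 to compound 2 (beyond the scatter), seen with hydroxy in place of methyl on an aromatic carbon. Going by the values given here, it is a modest step, and it is the only evidence available. Among the compounds with values here, no compound carrying bromine has been measured, so it offers only a rough guide. Since the hydroxy leaves again in compound 3, that compound is expected to move back towards compound 1, which stands at 95.3%, in this assay. The expected change is a modest rise, no larger than the earlier step: a number 6.3 percentage points higher from compound 2 to compound 3 (within the scatter). For compound 3 the estimated value is 90%, with an expected range of 76% to 99%.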

Compound 3, percent growth inhibition at one concentration: 94.3%
The estimate for compound 3 lay 4.3 percentage points below the measured number, and the stated range covers the measured number.
By their numbers in this assay, from the lowest: compound 2; then compounds 3 and 1 (each within the scatter of the next).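

In this assay, 4-bromophenyl in place of 3-hydroxyphenyl on the amide-type nitrogen gives a number 10.6 percentage points higher from compound 2 to compound 3 (beyond the scatter), the first sign that this position tolerates a group with a substituent other than methyl while holding the number close to that of compound 1. Compared with the 3-methylphenyl group, the 4-bromophenyl group gives a number 1 percentage points lower from compound 1 to compound 3 (within the scatter), so among these compounds the two without a hydroxy cannot be told apart, and only compound 2, with its 3-hydroxyphenyl group, stands apart from the others. No measurement shown here accounts for this difference.

Because the step from compound 2 to compound 3 changes both the substituent and its place on the ring, these compounds leave open how much each change contributes, a question that a 3-bromophenyl or a 4-hydroxyphenyl group on the same nitrogen could address. They also leave open whether an amine or a carboxylic acid on this ring would go with a lower number, as the hydroxy does in compound 2.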